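Swapping the bicyclic group on the amide carbonyl

The source may report more compounds than this note shows. Statements on the series, on what has been measured and on what is new or still open speak of the compounds shown alone.

- compound 1 `O=C(NCc1ccc(S(=O)(=O)c2ccccc2)cc1)c1ccc2ncncc2c1`: > 10000 nM
- compound 2 `O=C(NCc1ccc(S(=O)(=O)c2ccccc2)cc1)c1nc2cnccc2[nH]1`: 5400 nM

Among the measured compounds shown here, in a functional assay on A2780 cells (Homo sapiens) for inhibition, read by sulforhodamine B assay, with a stated time of 72 h (on this read-out lower numbers stand for stronger inhibition and higher numbers for weaker inhibition), compound 2 gives 5400 nM, the only true number so far. Compound 1 reads > 10000 nM, which is a limit of the assay and not a number.

Compound 3 `O=C(NCc1ccc(S(=O)(=O)c2ccccc2)cc1)c1cc2ccncc2s1` keeps the rest of compound 2 and changes the group on a carbonyl carbon: a group of 9 heavy atoms (7 carbon, 1 nitrogen, 1 sulfur; one five-membered aromatic ring with 1 hetero atom, one six-membered aromatic ring with 1 hetero atom) in place of a group of 9 heavy atoms (6 carbon, 3 nitrogen; one five-membered aromatic ring with 2 hetero atoms, one six-membered aromatic ring with 1 hetero atom), on a carbonyl carbon. For the measured compounds named here, no measured step guides the size of this change, but compound 2 at 5400 nM leaves ample room toward stronger inhibition. The expected move in this assay is toward stronger inhibition, an 18-fold lower number from compound 2 to compound 3 (1.26 log units; beyond the scatter), and this estimate is uncertain. For compound 3 the estimated value is 300 nM, with an expected range from 15 nM to 5000 nM.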

Compound 3, half-maximal inhibitory concentration: 14 nM
Beside the measured number, compound 3's estimate is 21-fold (1.33 log units) above it, and the stated range ends above it.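

In this assay, the group on the carbonyl carbon can decide between weak and strong inhibition: this single change gives a 390-fold lower number from compound 2 to compound 3 (2.59 log units; beyond the scatter). Both groups have the same number of heavy atoms, so that count does not separate them; they differ in their atoms and in hydrogen-bond donors. Nothing measured here explains the size of the step.

Still open, on these data alone, is whether the sulfur atom or the loss of the hydrogen-bond donor matters more. A matching group with an oxygen atom in place of the sulfur would help to separate the two.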